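Benzylamide variation on a bromonaphthyridine carboxamide series

This account rests on a few compounds, and the source may have more. Where it says the series, first, only, none or still open, it means among the compounds named here.

Measured so far:
- Compound 1 `N[C@H]1CC[C@H](Nc2c(C(=O)NCc3ccc(Oc4ccccc4)cc3)nc(Br)c3cccnc23)CC1`: 7900 nM
- Compound 2 `COc1ccc(CNC(=O)c2nc(Br)c3cccnc3c2N[C@H]2CC[C@H](N)CC2)cc1`: "not determined" (no result reported)

Among the measured compounds shown here, compound 1 is the only member of the set with a number in a functional assay on MCF7 cells (Homo sapiens) for cytotoxicity, read by MTT assay, with a stated time of 72 h (on this read-out lower numbers stand for stronger inhibition and higher numbers for weaker inhibition), where compound 1 gives 7900 nM. Compound 2 carries the same core and the same trans-diaminocyclohexyl substituent but a 4-methoxybenzyl amide instead of the phenoxybenzyl amide of compound 1; in this assay compound 2 stands as "not determined" (no result reported), so no comparison of compound 2 with compound 1 can be drawn beyond noting that one value exists and the other does not.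

Compound 3 `CN(C)c1ccc(CNC(=O)c2nc(Br)c3cccnc3c2N[C@H]2CC[C@H](N)CC2)cc1` is the next variation on the same amide position. It differs from compound 2 as follows: dimethylamino in place of methoxy on an aromatic carbon. Since compound 2 has no number, the size of the step from compound 2 to compound 3 cannot be anchored; with only compound 1 as a reference, nothing in the data points to a change in this assay beyond the usual scatter in either direction.

On that basis compound 3 is expected to sit near the potency of compound 1, estimated at 8000 nM, with a plausible range of 2000 nM to 30000 nM.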

Compound 3, half-maximal inhibitory concentration: 5000 nM
For compound 3 the middle estimate is 1.6-fold (0.20 log units) above the measured one; measured number inside the range.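

In this assay, among the compounds shown here, the exchange at this aromatic carbon of the benzyl amide gives a 1.6-fold lower number from compound 1 to compound 3 (0.20 log units; within the scatter), the first readable step, and it shows that dimethylamino in place of phenoxy does not separate the two compounds on this read-out. The position can therefore carry either a ring-bearing phenoxy group or dimethylamino, which has no ring, with the shared core and the trans-diaminocyclohexyl substituent unchanged and no difference beyond the usual scatter. No measurement here gives a reason for this result or relates it to any property of either group.

The step from compound 2 to compound 3 cannot be read, so the methoxy group remains unplaced relative to the other two substituents. As far as these compounds go, it also remains open whether a carboxylic acid, a primary amine or a longer alkoxy chain at this aromatic carbon would move the value beyond the scatter, or whether this position can shift the read-out at all.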